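This account rests on a few compounds, and the source may have more. Where it says the series, first, only, none or still open, it means among the compounds named here.

In a functional assay on MCF7 cells (Homo sapiens) for antiproliferative activity, read by MTT assay, with a stated time of 72 h (a lower number here means a stronger inhibitor, a higher number a weaker inhibitor), compound 1 (`C/C=C1/[C@H](O[C@@H]2O[C@H](CO)[C@@H](O)[C@H](O)[C@H]2O)OC=C(C(=O)OC)[C@H]1CC(=O)OCCCCCCCCCCCCCCC`) gives 2000 nM and compound 2 (`C/C=C1/[C@H](O[C@@H]2O[C@H](COC(C)=O)[C@@H](OC(C)=O)[C@H](OC(C)=O)[C@H]2OC(C)=O)OC=C(C(=O)OC)[C@H]1CC(=O)OCCCCCCCCCCCCCCC`) gives 9660 nM, while compound 3 (`C/C=C1/[C@H](O[C@@H]2O[C@H](CO)[C@@H](O)[C@H](O)[C@H]2O)OC=C(C(=O)OC)[C@H]1CC(=O)OCCC1CCCCC1`) gives 5000 nM in the same read-out. Compound 3 stands within the scatter of compound 2 and beyond the scatter of compound 1, whose number is lower. Compound 4 (`C/C=C1/[C@H](O[C@@H]2O[C@H](CO)[C@@H](O)[C@H](O)[C@H]2O)OC=C(C(=O)OC)[C@H]1CC(=O)OCCc1ccc(O)c(O)c1`) carries 3,4-dihydroxyphenyl in place of cyclohexyl on a saturated chain carbon, two bonds along the chain from an oxygen next to a carbonyl group. Going by the values given here, no measured step isolates this change, so only an expectation is possible: in this assay a higher number, beyond the scatter, with an estimated size (a 4.0-fold higher number from compound 3 to compound 4 (0.60 log units; beyond the scatter)). For compound 4 the estimated value is 20000 nM with an expected range from 6000 nM to 80000 nM in this series.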

Compound 4, half-maximal inhibitory concentration: 162000 nM
Compound 4: the middle estimate sits 8.1-fold (0.91 log units) below what was measured; the measured number lies above the stated range.
By their numbers in this assay, from the lowest: compound 1; then compounds 3 and 2 (each within the scatter of the next); then compound 4.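

In this assay, going by these compounds alone, the change from cyclohexyl to 3,4-dihydroxyphenyl, on a saturated chain carbon, two bonds along the chain from an oxygen next to a carbonyl group, brings a 32-fold higher number from compound 3 to compound 4 (1.51 log units; beyond the scatter) and is the first step that isolates one place. Within the data shown here, the group at this position can therefore move the number well beyond the scatter, which the earlier compounds could not show as a single step. Nothing available accounts for the size of this step.

From the compounds shown here alone, whether the step belongs to the aromatic ring or to its two hydroxyl groups stays open; a plain phenyl or a 3,4-dimethoxyphenyl on the same chain would separate the two.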